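The compounds below may be only part of what the source reports. "The series", "measured", "known", "first", "only" and "open" are said of these compounds alone.

Compound 3 `O=C(CC1Cc2ccc(-c3cc(F)cc(OC(F)F)c3)cc2N1S(=O)(=O)c1cccc(C(F)(F)F)c1)N1CC2(COC2)C1` stands lowest of the three compounds measured in an ADME assay on microsomes from liver (Mus musculus) for metabolic stability, read by LC-MS, using NADPH, with a stated time of 60 min, tested at 1 uM; a lower number here means that the compound disappears faster, a higher number that the compound lasts longer: compound 3 gives 0.0117 h, whereas compound 1 `O=C(O)CC1Cc2ccc(-c3cc(F)cc(OC(F)F)c3)cc2N1S(=O)(=O)c1cccc(C(F)(F)F)c1` gives 1.88 h and compound 2 `O=C(O)CCCC1Cc2ccc(-c3cc(F)cc(OC(F)F)c3)cc2N1S(=O)(=O)c1cccc(C(F)(F)F)c1` gives 1.56 h. The steps of a 160-fold lower number from compound 1 to compound 3 (2.21 log units; beyond the scatter) and a 130-fold lower number from compound 2 to compound 3 (2.12 log units; beyond the scatter) both accompany the move from an acid to an amide, while a 1.2-fold lower number from compound 1 to compound 2 (0.08 log units; within the scatter) is small. Compound 4 `O=C(CC1Cc2ccc(-c3cc(F)cc(OC(F)F)c3)cc2N1S(=O)(=O)c1cccc(C(F)(F)F)c1)N1CCS(=O)(=O)CC1` differs from compound 3 by a group of 8 heavy atoms (4 carbon, 1 nitrogen, 2 oxygen, 1 sulfur; one six-membered non-aromatic ring with 2 hetero atoms) in place of a group of 7 heavy atoms (5 carbon, 1 nitrogen, 1 oxygen; 2 four-membered non-aromatic rings with 1 hetero atom each), on a carbonyl carbon. Among the measured compounds shown here, no measured step compares two amides with each other, so the large drops seen on reaching compound 3 are only indirect guides. Because compound 3 gives 0.0117 h, compound 4 is expected to remain short-lived, with a 3.4-fold higher number from compound 3 to compound 4 (0.53 log units; beyond the scatter) as the estimated step. The estimate for compound 4 is 0.04 h, in the range 0.01 h to 0.2 h.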

Compound 4, half-life: 0.0333 h
Estimate against measurement, compound 4: 1.2-fold (0.08 log units) above; the range from low to high includes it.
By their numbers in this assay, from the lowest: compound 3; then compound 4; then compounds 2 and 1 (each within the scatter of the next).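

In this assay, the change of amide on this carbonyl carbon moves the half-life only slightly, with a 2.8-fold higher number from compound 3 to compound 4 (0.45 log units; beyond the scatter). Compound 4 still stands far from both acids, with a 56-fold lower number from compound 1 to compound 4 (1.75 log units; beyond the scatter) and a 47-fold lower number from compound 2 to compound 4 (1.67 log units; beyond the scatter), so the 1,1-dioxothiomorpholin-4-yl group recovers only a small part of the gap left by leaving the acid. Nothing measured here accounts for the difference between the two amides. The compounds shown leave open whether an open-chain dimethylamide or a piperazine amide on this carbonyl carbon would stand nearer the acids.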